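Replacing a diethylamine by a methylpiperazine on the basic chain

The compounds below may be only part of what the source reports. "The series", "measured", "known", "first", "only" and "open" are said of these compounds alone.

Compound 1 `O=c1cc(-c2ccccc2)oc2cc(O)c(OCCCN3CCCCC3)c(O)c12` in a functional assay on A549 cells (Homo sapiens) for antiproliferative activity, read by MTT assay, with a stated time of 48 h; on this read-out lower numbers stand for stronger inhibition and higher numbers for weaker inhibition: > 100000 nM, which is a limit of the assay and not a number.
Compound 2 `O=c1cc(-c2ccccc2)oc2cc(OCc3ccccc3)c(OCCCCN3CCCCC3)c(O)c12` in this assay: 1900 nM.
Compound 3 `CCN(CC)CCCCOc1c(OC)cc2oc(-c3ccccc3)cc(=O)c2c1O` in this assay: 35000 nM.

Of the two numbers measured in this assay, compound 3 holds the higher one, and the gap down to compound 2 lies beyond the scatter. Compound 1 contributes only a limit, (the limit of > 100000 nM in this assay, at which 1 of the 3 values shown sits), and nothing about the step at hand.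

Compound 4 `COc1cc2oc(-c3ccccc3)cc(=O)c2c(O)c1OCCCN1CCN(C)CC1` differs from compound 3 by 4-methylpiperazin-1-yl in place of (diethylamino)methyl on a saturated chain carbon, three bonds along the chain from an oxygen on an aromatic ring. For the measured compounds named here, no measured pair isolates this change, so its size is unknown; a step within the scatter, in either direction, is expected. Compound 4 is estimated at 30000 nM, between 8000 nM and 100000 nM, an expected step of a 1.2-fold lower number from compound 3 to compound 4 (0.07 log units; within the scatter).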

Compound 4, half-maximal inhibitory concentration: 18000 nM
Estimate against measurement, compound 4: 1.7-fold (0.22 log units) above; the range from low to high includes it.
By their numbers in this assay, from the lowest: compound 2; then compounds 4 and 3 (each within the scatter of the next). At a limit, above all of these: compound 1.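

Replacing (diethylamino)methyl with 4-methylpiperazin-1-yl at this chain carbon gives a 1.9-fold lower number from compound 3 to compound 4 (0.29 log units; within the scatter) in this assay, so this change to the amine end leaves the read-out indistinguishable from scatter. Read one bond further out, the same change takes 4-(diethylamino)butyl to 3-(4-methylpiperazin-1-yl)propyl, so the amine and the chain length change together here. Nothing measured here explains the step.

The separate contributions of the amine and the chain length cannot be read from these compounds. On these data alone, a morpholine or a pyrrolidine on either chain length remains open.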